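A few compounds are considered here, and "the series" means these few. Any claim that something is new, unique, unknown or untested is made for them only; others in the source may bear on it.

Among the compounds with values here, compound 3 `C#CCn1c(-c2ccc(C(=O)N/N=C/c3ccc(O)cc3)cc2)nc2ccccc21` gives the only plain number among the three compounds measured in an assay on cells for inhibition of Amine oxidase [flavin-containing] A (Homo sapiens), read by fluorescence and Amplex Red, with stated times of 30 min and 5 min (a lower number here means a stronger inhibitor, a higher number a weaker inhibitor), with a value of 2820 nM. Compound 1 `C#CCn1c(-c2ccc(C(=O)N/N=C/c3ccc[nH]3)cc2)nc2ccccc21` sits at a limit of the assay, reported in this assay as >= 1000000 nM. Compound 2 `C#CCn1c(-c2ccc(C(=O)N/N=C/c3cccn3C)cc2)nc2ccccc21` likewise reaches only a limit, reported in this assay as >= 100000 nM. The step from compound 1 to compound 2 is unreadable between these two limits (a step that the two limits leave unreadable from compound 1 to compound 2).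

Compound 4 `C#CCn1c(-c2ccc(C(=O)N/N=C/c3cccc(O)c3)cc2)nc2ccccc21` differs from compound 3 in one place: 3-hydroxyphenyl in place of 4-hydroxyphenyl on a carbon with a double bond to nitrogen. The two measured steps that reach compound 3 are large ones, an at least 350-fold lower number from compound 1 to compound 3 (2.54 log units; beyond the scatter) and an at least 35-fold lower number from compound 2 to compound 3 (1.54 log units; beyond the scatter), yet both exchange a whole hydroxyphenyl for a pyrrole ring, whereas the change here only moves the hydroxyl within the same ring. Within the data shown here, no measured pair shows such a move. The author therefore expects a modest step, a 1.8-fold higher number from compound 3 to compound 4 (0.25 log units; within the scatter), rather than anything of the size seen before. Compound 4 is estimated in this assay at 5000 nM, with a likely range from 1000 nM to 30000 nM.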

Compound 4, half-maximal inhibitory concentration: >= 1000000 nM
Compound 4: only a limit was reported; the forecaster's own chance of this, stated with the estimate: 15%; middle value at least 200-fold (2.30 log units) away from the limit.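

Moving the hydroxyl within the same ring, with the same atoms, is enough to change the result in this assay, a shift printed as an at least 350-fold higher number from compound 3 to compound 4 (2.54 log units; beyond the scatter). The earlier steps each exchanged a whole ring, so they could not show that, among the compounds shown, the plain number belongs to the 4-hydroxyphenyl group and not to the 3-hydroxyphenyl group, which carries the same atoms. Compound 4 is reported only as a limit: the limit of >= 1000000 nM in this assay, at which 2 of the 4 values shown sit.

The steps from compound 1 and from compound 2 to compound 4 cannot be read, as limits stand on both sides. The compounds shown leave open whether the hydroxyl itself is needed, as 4-methoxyphenyl or 4-aminophenyl in its place would test, and how 2-hydroxyphenyl would compare.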